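Replacing the methylcyclohexyl amide with a bicyclic group

The source may report more compounds than this note shows. Statements on the series, on what has been measured and on what is new or still open speak of the compounds shown alone.

Compound 2 `CC1CCC(C(=O)N2CC(c3nc(-c4cccc(Cl)c4)no3)C2)CC1` is measured in an assay on HEK293 cells for positive allosteric modulation of metabotropic glutamate receptor 5 (Homo sapiens), read by FLIPR (a higher number here means that more compound is needed for the effect, a lower number that less compound is needed), at 1500 nM, the highest of the two numbers in hand. Compound 3 `O=C([C@H]1CC2CCC1C2)N1CC(c2nc(-c3cccc(F)c3)no2)C1` gives 72 nM in this assay, a far lower number, beyond the scatter. For compound 1 `O=C(c1ccccc1F)N1CC[C@H]1c1nc(-c2cccc(F)c2)no1` this assay reports > 10000 nM, which is a limit and not a number; it is the limit of > 10000 nM in this assay, at which 1 of the 3 values shown sits.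

Compound 4 `O=C([C@@H]1CC2CCC1C2)N1CC(c2nc(-c3cccc(Cl)c3)no2)C1` differs from compound 2 by a group of 7 heavy atoms (7 carbon; 2 five-membered non-aromatic rings of carbon only) in place of a group of 7 heavy atoms (7 carbon; one six-membered non-aromatic ring of carbon only), on a carbonyl carbon, on a carbonyl carbon whose other neighbour is an amide-type nitrogen in a ring. Among the compounds with values here, no measured step of this kind exists, so the expectation rests on compound 3 with its 72 nM, which carries a closely related bicyclic group. Compound 4 is therefore expected at 150 nM, between 40 nM and 600 nM. The step is estimated at a 10-fold lower number from compound 2 to compound 4 (1.00 log units; beyond the scatter), downward and beyond the scatter.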

Compound 4, half-maximal effective concentration: 98 nM
For compound 4 the middle estimate is 1.5-fold (0.18 log units) above the measured one; the measured number falls inside the stated range.
By their numbers in this assay, from the lowest: compounds 3 and 4 (each within the scatter of the next); then compound 2. At a limit, above all of these: compound 1.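

In this assay, within the data shown here, placing the group with 2 five-membered non-aromatic rings of carbon only on the carbonyl carbon, in place of 4-methylcyclohexyl, gives a 15-fold lower number from compound 2 to compound 4 (1.18 log units; beyond the scatter), the first step that can be read at this position. The two groups have the same heavy-atom count, 7 carbon, and no hydrogen-bond donors or acceptors, so these counts do not separate them. Nothing measured here explains the step.

Still open, as far as these compounds go, is how the opposite configuration at the defined stereocentre compares. Also open, from the compounds shown here alone, is how a hydroxyl or an amine on the bicyclic group would read.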